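The source may hold more compounds than are shown below. What is called first, only, known or untested is meant among the compounds shown, and "the series" means these compounds.

Working notes on the oxadiazole-linked series in an ADME assay on liver (strain Wistar) for metabolic stability, with Liver microsome (Rattus norvegicus) as the target, read by LC-MS, using microsomes and NADPH, with a stated time of 15 min, tested at 1 uM; a lower number here means slower removal, a higher number faster removal of the compound. Compound 1 `CCc1cc(-c2noc(-c3cc(C)cc(CN(C)C)c3)n2)cc(C)c1OC[C@@H](O)CNC(=O)CO`, compound 2 `CCc1cc(-c2noc(-c3cc(C)cc(CN(C)CC)c3)n2)cc(C)c1OC[C@@H](O)CNC(=O)CO` and compound 3 `CCCCN(C)Cc1cc(C)cc(-c2nc(-c3cc(C)c(OC[C@@H](O)CNC(=O)CO)c(CC)c3)no2)c1` differ only in the substituents on saturated chain carbons around the amine nitrogen. In this assay compound 1 gives > 4800 mL.min-1.g-1, which is a limit of the assay and not a number. Compound 2 in this assay gives > 5000 mL.min-1.g-1, again a limit rather than a read number. Within the data shown here, compound 3 in this assay gives 7300 mL.min-1.g-1, the one read number of the three. The steps a step that the two limits leave unreadable from compound 1 to compound 2, a step that the limit leaves unreadable from compound 1 to compound 3 and a step that the limit leaves unreadable from compound 2 to compound 3 can therefore not be sized, because the limit of > 4800 mL.min-1.g-1 in this assay, at which 1 of the 3 values shown sits, and the limit of > 5000 mL.min-1.g-1 in this assay, at which 1 of the 3 values shown sits, place two of the three values at limits. Compound 2 thus stands at a limit, alongside compound 1 at a limit and compound 3 at a number.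

Compound 4 `CCc1cc(-c2nc(-c3cc(C)c(OC[C@@H](O)CNC(=O)CO)c(CC)c3)no2)ccc1CN(C)C` holds the same atoms joined differently: 4-((dimethylamino)methyl)-3-ethylphenyl in place of 3-((ethyl(methyl)amino)methyl)-5-methylphenyl on an aromatic carbon. Among the measured compounds shown here, no measured step yields a readable size for such a rearrangement, so no step beyond the scatter is expected, and the expected step that the limit leaves unreadable from compound 2 to compound 4 is taken as essentially flat. The estimate for compound 4 in this assay is 6000 mL.min-1.g-1, expected to lie between 3500 mL.min-1.g-1 and 10000 mL.min-1.g-1, with a fair chance that only a limit is reported again.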

Compound 4, intrinsic clearance in microsomes: 9200 mL.min-1.g-1
For compound 4 the middle estimate is 1.5-fold (0.19 log units) below the measured one; the range from low to high includes it.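

In this assay, among these compounds, no step to compound 4 can be read from compound 1 or from compound 2, since the values of both are limits of the assay and not numbers. The compounds shown leave open whether 4-((dimethylamino)methyl)-3-ethylphenyl in place of either starting group alters the rate of removal at all, and by how much.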